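Thiosemicarbazones on HL-60 cells: cyano replaced by methyl

A few compounds are considered here, and "the series" means these few. Any claim that something is new, unique, unknown or untested is made for them only; others in the source may bear on it.

The series gathers two measured thiosemicarbazones and one still to be tested. Compound 1 `N#Cc1ccc(NC(=S)N/N=C/c2ccc3ccccc3n2)cc1` is the only one with a numerical result: in a functional assay on HL-60 cells (Homo sapiens) for antiproliferative activity, read by sulforhodamine B assay, with a stated time of 72 h (on this read-out lower numbers stand for stronger inhibition and higher numbers for weaker inhibition), compound 1 gives 4660 nM. Compound 2 `NC(=S)N/N=C/c1nc2ccccc2s1` reaches only a limit of this assay; compound 2 gives > 100000 nM, which is a limit and not a number, so that (the limit of > 100000 nM in this assay, at which 1 of the 2 values shown sits). Going by the values given here, no step between measured compounds can be drawn from these two.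

Compound 3 `Cc1ccc(NC(=S)N/N=C/c2ccc3ccccc3n2)cc1` differs from compound 1 in one place: methyl in place of cyano on an aromatic carbon. Among the compounds with values here, with no measured step of this kind to lean on, the change is expected to move the result only modestly, and in the direction of a somewhat weaker inhibition. For compound 3 a value of 7000 nM is estimated, within 2300 nM to 21000 nM, which means an expected step of a 1.5-fold higher number from compound 1 to compound 3 (0.18 log units; within the scatter).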

Compound 3, half-maximal inhibitory concentration: 78300 nM
Estimate against measurement, compound 3: 11-fold (1.05 log units) below, outside the stated range (above it).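

In this assay, going by these compounds alone, methyl in place of cyano on this aromatic carbon gives a 17-fold higher number from compound 1 to compound 3 (1.23 log units; beyond the scatter), the first measured one-place comparison, and it shows that the result at this position depends strongly on the group it carries. Compound 3 still gives a numerical result, so this change weakens inhibition without taking the compound out of the measurable range. Within the data shown here, compound 2 remains the one compound at a limit, which is not a number: the limit of > 100000 nM in this assay, at which 1 of the 3 values shown sits.

This single pair cannot separate the effect of losing the nitrile from that of gaining the methyl, and the compounds shown do not tell how a methoxy group, an amine or a plain hydrogen would read on this carbon. Among these compounds, compound 2 differs from the others in more than one place, so no steps to it can be read.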